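Three measured analogues and one still awaiting cytotoxicity data

The source may hold more compounds than are shown below. What is called first, only, known or untested is meant among the compounds shown, and "the series" means these compounds.

Compound 1 `O=C(/C=C/c1ccc2c(c1)B(O)OC2)c1ccc(O)cc1`, compound 2 `O=C(/C=C/c1ccc2c(c1)B(O)OC2)c1ccc(F)cc1` and compound 3 `O=C(/C=C/c1ccc2c(c1)B(O)OC2)c1cccc(F)c1` share one core and were tested in an ADME assay on L929 cells (Mus musculus) for cytotoxicity, read by resazurin assay, with a stated time of 72 h; a higher number here means a weaker inhibitor, a lower number a stronger inhibitor. In this assay compound 1 gives only a limit, > 10 ug/mL. Compound 2 likewise gives only a limit, > 10 ug/mL. Compound 3 also gives only a limit, > 10 ug/mL. The change from compound 2 to compound 1 is hydroxy in place of fluoro on an aromatic carbon, and its step is a step that the two limits leave unreadable from compound 2 to compound 1. The cores of compound 2 and compound 3 differ by 3-fluorophenyl in place of 4-fluorophenyl on a carbonyl carbon, with a step that the two limits leave unreadable from compound 2 to compound 3. Compound 4 `O=C(/C=C/c1ccc2c(c1)B(O)OC2)c1cccc(O)c1` is not yet measured; it differs from compound 3 by hydroxy in place of fluoro on an aromatic carbon, the same kind of change as from compound 2 to compound 1, though here meta to a large group rather than para. Since all three values sit at the limit of > 10 ug/mL in this assay, at which 3 of the 3 values shown sit, compound 4 is expected to show a step that the limit leaves unreadable from compound 3 to compound 4. Compound 4 is estimated at 15 ug/mL, between 7 ug/mL and 40 ug/mL.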

Compound 4, half-maximal inhibitory concentration: 7.56 ug/mL
For compound 4 the middle estimate is 2.0-fold (0.30 log units) above the measured one, within the range that was stated.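

In this assay the replacement of fluoro by hydroxy gives an at least 1.3-fold lower number from compound 3 to compound 4 (0.12 log units; that floor lies within the scatter), and compound 4 also shows an at least 1.3-fold lower number from compound 2 to compound 4 (0.12 log units; that floor lies within the scatter) and an at least 1.3-fold lower number from compound 1 to compound 4 (0.12 log units; that floor lies within the scatter). The same replacement on the other aromatic position, from compound 2 to compound 1, joins two limits, so that step and the other steps among compounds 1, 2 and 3 cannot be read: the limit of > 10 ug/mL in this assay, at which 3 of the 4 values shown sit. Compound 4 therefore gives a readable floor for the replacement in one setting only, and the data show neither that it carries over from one setting to the other nor that it fails to.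

The compounds shown leave open how an amine or a carboxylic acid in place of the hydroxy would read in this assay. Going by these compounds, a methoxy group at either position also remains open.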